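The source may report more compounds than this note shows. Statements on the series, on what has been measured and on what is new or still open speak of the compounds shown alone.

Values in a functional assay on A2780 cells (Homo sapiens) for antiproliferative activity, read by MTT assay, with a stated time of 48 h (a higher number here means a weaker inhibitor, a lower number a stronger inhibitor), are as follows
- compound 1 `COc1ccc2c(/C=C/C(=O)c3cc(OC)c(OC)c(SC)c3)c[nH]c2c1` gives 139 nM
- compound 2 `COc1ccc2c(/C=C/C(=O)c3cc(N)c(OC)c(OC)c3)c[nH]c2c1` gives 204 nM
- compound 3 `COc1ccc2c(/C=C/C(=O)c3cc(N)c(OC)c(OC)c3)cn(C)c2c1` gives 156 nM

Compound 2 stands within the scatter of both compound 1 and compound 3, so the three measured compounds cannot be ranked on these numbers. Compound 4 `COc1ccc2c(/C=C/C(=O)c3cc(OC)c(OC)c([N+](=O)[O-])c3)c[nH]c2c1` has not yet been measured. It departs from compound 2 by nitro in place of amino on an aromatic carbon, and the count of that change reads (nitro in place of amino on an aromatic carbon).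

The closest evidence is a change on the same aromatic carbon, which gave a 1.5-fold higher number from compound 1 to compound 2 (0.17 log units; within the scatter). The other measured step, a 1.3-fold lower number from compound 2 to compound 3 (0.12 log units; within the scatter), lies on an aromatic nitrogen and bears on the new change only indirectly. Both stayed within the scatter, and compound 1 at 139 nM shows that this carbon has tolerated a group other than amino. For the measured compounds named here, no measured compound carries nitro, however, so the evidence is thin and the range must stay wide. In this assay no step beyond the scatter is expected, with a slight lean towards a higher number. The estimate amounts to a 1.2-fold higher number from compound 2 to compound 4 (0.09 log units; within the scatter), an expected step of modest size. For compound 4 the expected value is 250 nM, within an estimated range from 70 nM to 900 nM.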

Compound 4, half-maximal inhibitory concentration: 742 nM
Compound 4: middle estimate off by 3.0-fold (0.47 log units), on the low side, within the range that was stated.
By their numbers in this assay, from the lowest: compounds 1, 3 and 2 (each within the scatter of the next); then compound 4.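

In this assay, for the compounds shown here, this aromatic carbon, ortho to a methoxy group, proved less tolerant than the earlier compounds had suggested. Amino and methylsulfanyl had stayed within the scatter of each other, whereas nitro gave a 3.6-fold higher number from compound 2 to compound 4 (0.56 log units; beyond the scatter) and a 5.3-fold higher number from compound 1 to compound 4 (0.73 log units; beyond the scatter) with both steps in the same direction. Going by these compounds alone, these are the first steps at this position that lie beyond the scatter, so the carbon does not accept every group alike, although both steps remain modest in size. Nothing available here accounts for the loss seen with nitro.

The compounds shown leave open whether the loss belongs to nitro alone or extends to other groups at this carbon, such as a nitrile, a carboxylic acid or a longer chain like ethylsulfanyl. They also leave open whether methyl on the aromatic nitrogen, a change that stayed within the scatter between the two amino compounds, would alter the result when nitro occupies this carbon.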